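A few compounds are considered here, and "the series" means these few. Any claim that something is new, unique, unknown or untested is made for them only; others in the source may bear on it.

Three compounds have been measured so far:

- Compound 1 `COc1ccc(C(=O)/C=C/c2ccc3ccccc3c2)c2c1C=CC(C)(C)O2` gives 4480 nM
- Compound 2 `CCN(CC)c1ccc(/C=C/C(=O)c2ccc(OC)c3c2OC(C)(C)C=C3)cc1` gives 550 nM
- Compound 3 `COc1ccc(C(=O)/C=C/c2cccc([N+](=O)[O-])c2)c2c1C=CC(C)(C)O2` gives 4260 nM

All three share the same core and differ only in the aromatic ring attached to the double bond. They were tested in a functional assay on HT-29 cells (Homo sapiens) for antiproliferative activity, read by MTT assay, with a stated time of 24 h; on this read-out higher numbers stand for weaker inhibition and lower numbers for stronger inhibition. Compound 3 stands second highest of the three numbers. Its nearest neighbour is compound 1, whose value is within the usual scatter, so the two cannot be told apart. Compound 2 lies furthest away, with a number well below the scatter, and so is the stronger inhibitor of the pair.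

The next compound to be measured is compound 4 `COc1ccc(C(=O)/C=C/c2cccc(O)c2)c2c1C=CC(C)(C)O2`. Compared with compound 3 the difference is hydroxy in place of nitro on an aromatic carbon. Among the compounds with values here, no measured pair shows this exact change, so its effect is unknown from the data here. Since the nitro and hydroxy groups sit at the same place, meta to a large group, the step is expected to be small: compound 4 is estimated at 3500 nM, with a range from 1200 nM to 10000 nM. This means an expected step of a 1.2-fold lower number from compound 3 to compound 4 (0.09 log units; within the scatter), not beyond the scatter.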

Compound 4, half-maximal inhibitory concentration: > 10000 nM
Compound 4: a limit, no number; the forecaster's own chance of this, stated with the estimate: 5%; at least 2.8-fold (0.45 log units) between middle value and limit.
By their numbers in this assay, from the lowest: compound 2; then compounds 3 and 1 (each within the scatter of the next). At a limit, above all of these: compound 4.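

In this assay compound 4 gives > 10000 nM, which is a limit of the assay and not a number. Within the data shown here, putting hydroxy in place of nitro on this aromatic carbon, meta to a large group, gives an at least 2.3-fold higher number from compound 3 to compound 4 (0.37 log units; beyond the scatter); this is the first step that changes a single place, and it shows that the group at this position matters to the read-out, even though both groups are small and sit at the same place. The step's printed size is only a minimum, and its true size cannot be read because the measurement ends at a limit: the limit of > 10000 nM in this assay, at which 1 of the 4 values shown sits.

This one pair cannot tell whether the change in the read-out comes from gaining the hydroxy or from losing the nitro, and a plain hydrogen at the same place would be the natural reference for separating the two. It also leaves open how other groups on this carbon, such as a methoxy, a fluorine atom or a carboxylic acid, would fall relative to these two.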